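The compounds below may be only part of what the source reports. "The series", "measured", "known", "first", "only" and "open" are said of these compounds alone.

Measured compounds in the series:

compound 1, `FC(F)(F)c1ccc(/C=C\c2cc3ccccc3nc2Cl)cc1`, in a functional assay on MDA-MB-468 cells (Homo sapiens) for antiproliferative activity, read by sulforhodamine B assay, with a stated time of 72 h (on this read-out lower numbers stand for stronger inhibition and higher numbers for weaker inhibition), gives 7380 nM
compound 2, `FC(F)(F)c1ccc(/C=C\c2cc3ccc(Cl)cc3nc2Cl)cc1`, in this assay gives 16100 nM
compound 3, `FC(F)(F)c1cc(/C=C\c2cc3ccccc3nc2Cl)cc(C(F)(F)F)c1`, in this assay gives 10500 nM

Compound 1 and compound 2 share a core and differ in one place, as follows.

chloro in place of hydrogen on an aromatic carbon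

This change gave a 2.2-fold higher number from compound 1 to compound 2 (0.34 log units; beyond the scatter). Compound 3 carries a second trifluoromethyl group on the pendant ring; the difference between its core and the core of compound 1 is not broken down here. Its value in this assay sits within the scatter of both compound 1 and compound 2, so no order among the three is claimed.

Compound 4, `FC(F)(F)c1cc(/C=C\c2cc3ccc(Cl)cc3nc2Cl)cc(C(F)(F)F)c1`, has not been measured. It differs from compound 3 as follows.

chloro in place of hydrogen on an aromatic carbon

The place is described in the same words as for the step from compound 1 to compound 2, so this is the same change, chloro in place of hydrogen on an aromatic carbon, made now on the core of compound 3. For the measured compounds named here, the only precedent is the single step from compound 1 to compound 2, and it is modest in size, so the expectation for compound 4 rests on one observation.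

For compound 4 a step of a 2.1-fold higher number from compound 3 to compound 4 (0.32 log units; beyond the scatter) is expected in this assay, of about the size seen from compound 1 to compound 2, because a 2.2-fold higher number from compound 1 to compound 2 (0.34 log units; beyond the scatter) was the outcome of the same change. Compound 4 is estimated at 22000 nM, with a likely range from 9000 nM to 50000 nM.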

Compound 4, half-maximal inhibitory concentration: > 50000 nM
Compound 4: a limit, no number; the forecaster's own chance of this, stated with the estimate: 15%; middle value at least 2.2-fold (0.35 log units) from the limit.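

Chloro in place of hydrogen on an aromatic carbon moves the number in the same direction on both cores in this assay, and on the core of compound 3 the outcome is an at least 4.7-fold higher number from compound 3 to compound 4 (0.67 log units; beyond the scatter). This shared direction rests on two pairs only, and what carries over between the cores is that direction, not a size: the same change on two cores in this assay, a 2.2-fold higher number (0.34 log units; beyond the scatter) from compound 1 to compound 2 and an at least 4.7-fold higher number (0.67 log units; beyond the scatter) from compound 3 to compound 4; the limit leaves it open whether they differ. Compound 4 gives > 50000 nM, which is a limit of the assay and not a number: the limit of > 50000 nM in this assay, at which 1 of the 4 values shown sits.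

The compounds shown carry only hydrogen or chloro at this place on the shared core, so it remains open whether a different group there, such as a methoxy, an amine or a carboxylic acid, would also move the number in this direction. Also open, as far as these compounds go, is whether the chloro step would keep its direction in this assay on a core whose pendant ring bears a nitrile or a methoxy in place of trifluoromethyl.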